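Nitro for methoxy in the bromo series: working notes

The source may hold more compounds than are shown below. What is called first, only, known or untested is meant among the compounds shown, and "the series" means these compounds.

Measured in a functional assay on B16-F10 cells (Mus musculus) for inhibition, read by MTT assay, with a stated time of 72 h; a higher number here means a weaker inhibitor, a lower number a stronger inhibitor:
- compound 1 `COc1ccc(NC(=S)NC2CC(C)(C)Oc3ccc(Br)cc32)cc1` gives "not determined" (no result reported)
- compound 2 `CC1(C)CC(NC(=S)Nc2cccc(C#N)c2)c2cc(Br)ccc2O1` gives 7000 nM
- compound 3 `CC1(C)CC(NC(=O)Nc2ccccc2Cl)c2cc(Cl)ccc2O1` gives 20000 nM

Compound 1 has no number in this assay, so its place among the measured compounds cannot be fixed. Among the compounds with values here, only two measured values frame the series: compound 2 at 7000 nM and compound 3 at 20000 nM. The next compound is compound 4 `CC1(C)CC(NC(=S)Nc2ccc([N+](=O)[O-])cc2)c2cc(Br)ccc2O1`, which carries nitro in place of methoxy on an aromatic carbon. The group sits on a six-membered aromatic ring of carbon only, para to a large group. Within the data shown here, no measured step covers this change, and without a starting value for compound 1 neither its size nor its direction can be anchored. No large departure from the measured range is expected, and the expectation rests only on compound 2 at 7000 nM and compound 3 at 20000 nM, with the range kept wide. For compound 4 the estimated value is 9000 nM, with an expected range of 3000 nM to 25000 nM.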

Compound 4, half-maximal inhibitory concentration: 3000 nM
Compound 4: the middle estimate sits 3.0-fold (0.48 log units) above what was measured; low and high end bracket the measured number.
By their numbers in this assay, from the lowest: compound 4; then compound 2; then compound 3.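

In this assay, within the data shown here, compound 1 gives "not determined" (no result reported), so no step from compound 1 to compound 4 can be read. As far as these compounds go, what replacing methoxy with nitro does to the value stays open. Nothing available bears on the result of compound 4.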